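The compounds below may be only part of what the source reports. "The series", "measured", "known", "first", "only" and "open" are said of these compounds alone.

Measured compounds:
Compound 1, `CC#C[C@@H](Cc1nnn[nH]1)c1ccc(OCc2ccc3sc(F)c(-c4ccc(OCCOC)cc4C)c3c2)cc1`: 24 nM
Compound 2, `CC#C[C@@H](Cc1nnn[nH]1)c1ccc(OCc2ccc3sc(C)c(-c4ccccc4C)c3c2)cc1`: 10 nM

Both compounds were characterised in a functional assay on cells for agonist activity at Free fatty acid receptor 1 (Rattus norvegicus), read by FLIPR and calcium flux; on this read-out lower numbers stand for an effect already at smaller amounts and higher numbers for an effect only at larger amounts of compound. Compound 2 stands at the lower of the two numbers, and compound 1 sits at a higher number, with the gap between them beyond the usual scatter of this assay. Compound 1 and compound 2 differ in more than one place, so nothing can be read from their two values about any single change.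

Compound 3, `CC#C[C@@H](Cc1nnn[nH]1)c1ccc(OCc2ccc3sc(C)c(-c4ccc(OCCOC)cc4C)c3c2)cc1`, is the next compound to be examined. It differs from compound 2 in one place: 2-methoxyethoxy in place of hydrogen on an aromatic carbon. Among the compounds with values here, compound 1, the only other measured compound that carries the 2-methoxyethoxy group, sits at the higher number in this assay, but it also differs elsewhere. The step of a 1.5-fold higher number from compound 2 to compound 3 (0.18 log units; within the scatter) is expected to stay within the scatter, with a slight shift to a higher number possible. Compound 3 is estimated to give 15 nM, within a range from 5 nM to 45 nM.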

Compound 3, half-maximal effective concentration: 32 nM
Estimate against measurement, compound 3: 2.1-fold (0.33 log units) below; low and high end bracket the measured number.
By their numbers in this assay, from the lowest: compound 2; then compounds 1 and 3 (each within the scatter of the next).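

In this assay, 2-methoxyethoxy in place of hydrogen on the aromatic carbon para to a large group gives a 3.2-fold higher number from compound 2 to compound 3 (0.51 log units; beyond the scatter), so this one change alone moves the number beyond the scatter, though only modestly. The swap at the other place, methyl in place of fluoro on an aromatic carbon, gives a 1.3-fold higher number from compound 1 to compound 3 (0.12 log units; within the scatter), which lies within the scatter and so shows no separable change in this pair. Nothing measured here explains the step at the 2-methoxyethoxy position.

As far as these compounds go, it remains open whether a methoxy group, a longer ether chain, an amine or a carboxylic acid on this carbon would give a similar step. From the compounds shown here alone, it is also open whether the step from hydrogen to 2-methoxyethoxy would be the same size with fluoro in place of methyl.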